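Nitro for trifluoromethyl on two related cores

The source may hold more compounds than are shown below. What is called first, only, known or untested is meant among the compounds shown, and "the series" means these compounds.

Compound 1 `CC1=NC(=S)N(C(=O)OC2CCN(Cc3ccccc3)CC2)C(c2ccccc2C(F)(F)F)/C1=C(\O)OC(C)C` and compound 2 `CC1=NC(=S)N(C(=O)OC2CCN(Cc3ccccc3)CC2)C(c2ccccc2[N+](=O)[O-])/C1=C(\O)OC(C)C` share one core; compound 3 `CC1=C(C(=O)OC(C)C)C(c2ccccc2C(F)(F)F)N(C(=O)OC2CCN(Cc3ccccc3)CC2)C(=O)N1` and compound 4 `CC1=C(C(=O)OC(C)C)C(c2ccccc2[N+](=O)[O-])N(C(=O)OC2CCN(Cc3ccccc3)CC2)C(=O)N1` share another, and the difference between the two cores is not broken down here. In a functional assay (aorta) for inhibition, with Oryctolagus cuniculus as the target (on this read-out lower numbers stand for stronger inhibition and higher numbers for weaker inhibition), compound 1 gives 5 nM, compound 2 gives 2 nM and compound 3 gives 50 nM, the highest number of the three measured. The change from compound 1 to compound 2, (nitro in place of trifluoromethyl on an aromatic carbon), made a 2.5-fold lower number from compound 1 to compound 2 (0.40 log units; beyond the scatter). The same change, (nitro in place of trifluoromethyl on an aromatic carbon), is made on the second core and occurs in two places among the compounds shown. The step is expected to be of like size, a 2.5-fold lower number from compound 3 to compound 4 (0.40 log units; beyond the scatter), resting on a single measured instance, because on the other core the step was a 2.5-fold lower number from compound 1 to compound 2 (0.40 log units; beyond the scatter). Compound 4 is thus estimated at 20 nM, between 8 nM and 60 nM.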

Compound 4, half-maximal inhibitory concentration: 8 nM
Compound 4: middle estimate off by 2.5-fold (0.40 log units), on the high side, within the range that was stated.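

The step on the second core reads a 6.3-fold lower number from compound 3 to compound 4 (0.80 log units; beyond the scatter) in this assay and points the same way as the step on the first core. The direction of the change carries over, and its size does not separate the two cores: the same change on two cores in this assay, a 2.5-fold lower number (0.40 log units; beyond the scatter) from compound 1 to compound 2 and a 6.3-fold lower number (0.80 log units; beyond the scatter) from compound 3 to compound 4, 2.5-fold (0.40 log units) apart, within the scatter of two such steps
Among these compounds, this rests on only two pairs in a single assay, so it gives no rule for other cores and no reason for the lower numbers.

Open, as far as these compounds go, is whether an amine, a nitrile or a plain hydrogen on that aromatic carbon would compare with 2-nitrophenyl. Also open, from the compounds shown here alone, is whether the step would persist with a longer ester chain on either core.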